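Ethyl on the ring nitrogen of compound 2

A few compounds are considered here, and "the series" means these few. Any claim that something is new, unique, unknown or untested is made for them only; others in the source may bear on it.

Measured in a functional assay on the whole organism with Rattus norvegicus as the target; a higher number here means that more compound is needed for the effect, a lower number that less compound is needed:
compound 1 `CCOC(=O)C(=O)Nc1cc(N(C)C)ccc1C#N`: > 100 mg/kg (a limit)
compound 2 `CCOC(=O)C(=O)Nc1cccc(NC)c1C#N`: 0.1 mg/kg
compound 3 `CNc1cccc(NC(=O)C(=O)O)c1C#N`: 0.07 mg/kg

Compound 1 gives > 100 mg/kg, which is a limit of this assay and not a number. Going by the values given here, compound 2 has only one numeric neighbour, and the two values sit within the scatter of each other: the measured step is a 1.4-fold lower number from compound 2 to compound 3 (0.15 log units; within the scatter). That step does not touch the nitrogen on the aromatic ring, so it says little about the change considered here.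

Compound 4 `CCOC(=O)C(=O)Nc1cccc(N(C)CC)c1C#N` carries ethyl in place of hydrogen on a nitrogen on an aromatic ring, which turns methylamino to ethyl(methyl)amino. Among the compounds with values here, no measured step covers this change. The estimate therefore starts from compound 2 at 0.1 mg/kg and keeps a wide margin. A modest move toward a higher number in this assay is expected, with the estimated size a 4.0-fold higher number from compound 2 to compound 4 (0.60 log units; beyond the scatter) held only loosely. Compound 4 is expected at 0.4 mg/kg, with an estimated range of 0.05 mg/kg to 5 mg/kg.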

Compound 4, dose for half-maximal effect: 0.5 mg/kg
Estimate against measurement, compound 4: 1.3-fold (0.10 log units) below; the range from low to high includes it.
By their numbers in this assay, from the lowest: compounds 3 and 2 (each within the scatter of the next); then compound 4. At a limit, above all of these: compound 1.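

Going by these compounds alone, the first measured step on the nitrogen on the aromatic ring is a 5.0-fold higher number from compound 2 to compound 4 (0.70 log units; beyond the scatter), so this site responds to substitution in this assay, unlike the ester step, which stays within the scatter. The hydrogen on this nitrogen is not needed for a measurable effect, since the change from methylamino to ethyl(methyl)amino costs only a modest amount and compound 4 still gives a numeric value rather than a limit. Nothing measured here bears on why the step has this size.

Open, on these data alone, is whether the size of the step tracks the group on this nitrogen: a second methyl, a propyl chain or the unsubstituted amine would test that. Also open, as far as these compounds go, is whether the carboxylic acid in place of the ethyl ester behaves on the ethyl(methyl)amino compound as it does on the methylamino compounds.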